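Halogen swap on the benzyl arm of the shared core

The source may hold more compounds than are shown below. What is called first, only, known or untested is meant among the compounds shown, and "the series" means these compounds.

Two members of the series have been measured. Compound 1 `COc1ccc(C2N=C(SCc3ccc(F)cc3)NC(C)=C2C(=O)Nc2ccc(F)cc2)cc1OC` in a functional assay on the whole organism (artery, strain albino) with Rattus norvegicus as the target, with a stated time of 600 min, at a dose of 10 mg/kg by the oral route (on this read-out lower numbers stand for less inhibition and higher numbers for more inhibition at the one dose given (going by the name of the read-out)), gives 21%. Compound 2 `CC1=C(C(=O)Nc2ccc(F)cc2)C(c2ccc([N+](=O)[O-])cc2)N=C(SCc2ccc(Cl)cc2)N1` in this assay gives 28.2%. The number of compound 2 is the larger of the two shown, yet the gap to compound 1 lies within the usual scatter of repeated measurements, so no order between the two can be read from the data. Among the measured compounds shown here, no pair of measured compounds differing in a single place is available; compounds 1 and 2 differ at more than one place, and what each of those differences contributes cannot be separated.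

Compound 3 `CC1=C(C(=O)Nc2ccc(F)cc2)C(c2ccc([N+](=O)[O-])cc2)N=C(SCc2ccc(F)cc2)N1` is not yet measured. Set against compound 2 it shows (fluoro in place of chloro on an aromatic carbon). The 4-fluorobenzyl group also occurs in compound 1, but the two measured values give no isolated reading of this exchange, and they are themselves within the scatter of each other. The step from compound 2 to compound 3 is therefore expected to stay within the scatter, a number 3.2 percentage points lower from compound 2 to compound 3 (within the scatter), with no firm direction. Compound 3 is estimated at 25%, between 10% and 40%.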

Compound 3, a percentage reported as inhibition, in the whole organism at one dose (the size of the read-out at that dose, not a potency): 25.6%
The estimate for compound 3 lay 0.6 percentage points below the measured number; the range from low to high includes it.
By their numbers in this assay, from the lowest: compounds 1, 3 and 2 (each within the scatter of the next).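

In this assay, the exchange on the benzyl arm can now be read on its own: fluoro in place of chloro on an aromatic carbon, para to a large group, gives a number 2.6 percentage points lower from compound 2 to compound 3 (within the scatter) and so does not separate the two halogens at this place. Among the compounds shown here, the group on the saturated ring carbon can also be read on its own for the first time: 4-nitrophenyl in place of 3,4-dimethoxyphenyl gives a number 4.6 percentage points higher from compound 1 to compound 3 (within the scatter) and so does not separate these two groups at the one dose given. No measurement bears on the reason for either result.

As far as these compounds go, both readings cover only these exchanges, so it remains open whether the benzyl arm gives a step beyond the scatter with a carboxylic acid or an amine in place of the halogen, or with a longer chain in place of the benzyl group. The saturated ring carbon is open in the same way, since the compounds shown carry only 4-nitrophenyl and 3,4-dimethoxyphenyl there, and a step beyond the scatter at either place has yet to appear in this series.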